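The source may hold more compounds than are shown below. What is called first, only, known or untested is meant among the compounds shown, and "the series" means these compounds.

Measured so far in a functional assay on HCT-116 cells (Homo sapiens) for inhibition, read by MTT assay, with a stated time of 48 h; on this read-out lower numbers stand for stronger inhibition and higher numbers for weaker inhibition: compound 1 `COc1cc(-c2cc(-c3ccc(N)cc3)nc(-c3ccccc3)n2)cc(OC)c1OC` gives 12300 nM; compound 2 `COc1cc(-c2cc(-c3cccc(O)c3)nc(-c3ccccc3)n2)cc(OC)c1OC` gives 20400 nM; compound 3 `COc1cc(-c2cc(-c3cccc4ccccc34)nc(-c3ccccc3)n2)cc(OC)c1OC` gives 4930 nM.

Compound 1 stands second highest of the three numbers, with compound 2 within the scatter of it and compound 3 the furthest from it. Compound 4 `COc1cc(-c2cc(-c3cccs3)nc(-c3ccccc3)n2)cc(OC)c1OC` differs from compound 1 in one place: thiophen-2-yl in place of 4-aminophenyl on an aromatic carbon. Both measured steps start from compound 1. a 1.7-fold higher number from compound 1 to compound 2 (0.22 log units; within the scatter), with a hydrogen-bond donor kept, stays within the scatter. a 2.5-fold lower number from compound 1 to compound 3 (0.40 log units; beyond the scatter), with the donor gone and naphthalen-1-yl entering, moves modestly. Compound 4 also gives up the donor, so a modest downward step in this assay is expected, estimated as a 1.5-fold lower number from compound 1 to compound 4 (0.19 log units; within the scatter). Compound 4 is therefore expected at 8000 nM, with a range from 3000 nM to 25000 nM.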

Compound 4, half-maximal inhibitory concentration: 17000 nM
Estimate against measurement, compound 4: 2.1-fold (0.33 log units) below; low and high end bracket the measured number.
By their numbers in this assay, from the lowest: compound 3; then compounds 1, 4 and 2 (each within the scatter of the next).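

In this assay the donor-free thiophen-2-yl group shows a 1.4-fold higher number from compound 1 to compound 4 (0.14 log units; within the scatter) and a 1.2-fold lower number from compound 2 to compound 4 (0.08 log units; within the scatter) against the donor-bearing groups, so losing the hydrogen-bond donor at this position does not by itself bring the lower number seen for compound 3. Compound 3 also lacks the donor, yet a 3.4-fold higher number from compound 3 to compound 4 (0.54 log units; beyond the scatter) separates it from compound 4, so the donor-free groups do not behave alike here.

From the compounds shown here alone, whether a second fused bicyclic group such as quinolin-8-yl, or a plain phenyl, would sit with compound 3 or with compound 4 remains open. Nothing measured here bears on why naphthalen-1-yl stands apart.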